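A few compounds are considered here, and "the series" means these few. Any claim that something is new, unique, unknown or untested is made for them only; others in the source may bear on it.

Compounds measured so far:
- compound 1 `COc1cc(/C=C/c2ccc(S(N)(=O)=O)cc2)cc(OC)c1`: 16200 nM
- compound 2 `NS(=O)(=O)c1ccc(/C=C/c2ccc(F)cc2)cc1`: 29400 nM
- compound 3 `NS(=O)(=O)c1ccc(/C=C/c2ccc(O)c(O)c2)cc1`: 35400 nM

In a functional assay on HT-29 cells (Homo sapiens) for inhibition (a lower number here means a stronger inhibitor of growth, a higher number a weaker inhibitor of growth), compound 3 holds the highest number of the three, though the number of compound 2 sits within the scatter of it; only compound 1 lies beyond the scatter, with the lower number. Compound 4 `NS(=O)(=O)c1ccc(/C=C/c2ccc(O)cc2)cc1` has not been measured. It differs from compound 3 in one place: hydrogen in place of hydroxy on an aromatic carbon. Within the data shown here, no pair of measured compounds shows this kind of change, so there is no step to lean on. The step from compound 3 to compound 4 is expected to stay within the scatter, with a slight lean toward a lower number. For compound 4 the estimate is 28000 nM, expected to fall between 11000 nM and 70000 nM, which means an expected 1.3-fold lower number from compound 3 to compound 4 (0.10 log units; within the scatter).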

Compound 4, concentration for 50% growth inhibition: 17800 nM
Compound 4: middle estimate off by 1.6-fold (0.20 log units), on the high side; the measured number falls inside the stated range.
By their numbers in this assay, from the lowest: compounds 1, 4, 2 and 3 (each within the scatter of the next, the first and the last beyond it).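

In this assay, hydrogen in place of hydroxy on this aromatic carbon gives a 2.0-fold lower number from compound 3 to compound 4 (0.30 log units; within the scatter), and hydroxy in place of fluoro gives a 1.7-fold lower number from compound 2 to compound 4 (0.22 log units; within the scatter). Neither single change moves the number beyond the scatter, so neither step separates these groups in this assay. No measurement available here bears on this result. Going by these compounds, it remains open what an amine or a carboxylic acid on this aromatic carbon would give. On these data alone, it also remains open whether any single change on this ring leads beyond the scatter.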